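This account rests on a few compounds, and the source may have more. Where it says the series, first, only, none or still open, it means among the compounds named here.

Measured values in a functional assay on MCF7 cells (Homo sapiens) for inhibition, read by sulforhodamine B assay; on this read-out higher numbers stand for weaker inhibition and lower numbers for stronger inhibition:
- Compound 1 `CCc1ccc(NC2=CC(=O)c3c(nc4n3[C@H]3OC[C@@H](O)[C@H]3OC4)C2=O)cc1`: 8990 nM
- Compound 2 `O=C1C(N2CCCC2)=CC(=O)c2c1nc1n2[C@H]2OC[C@@H](O)[C@H]2OC1`: > 16000 nM, a limit
- Compound 3 `O=C1C(Nc2ccc(C(F)(F)F)cc2)=CC(=O)c2c1nc1n2[C@H]2OC[C@@H](O)[C@H]2OC1`: > 4000 nM, a limit

Compound 3 sits at the limit of > 4000 nM in this assay, at which 1 of the 3 values shown sits, so it has a limit and not a number. Compound 4 `COc1cccc(NC2=CC(=O)c3c(nc4n3[C@H]3OC[C@@H](O)[C@H]3OC4)C2=O)c1` keeps the shared core and differs from compound 3 in one place: 3-methoxyphenyl in place of 4-(trifluoromethyl)phenyl on an amine nitrogen. In words, 3-methoxyphenyl stands in place of 4-(trifluoromethyl)phenyl on an amine nitrogen.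

For the measured compounds named here, two measured steps bear on this change. The closer one, a step that the limit leaves unreadable from compound 1 to compound 3, also alters a group on the phenyl ring, but its size cannot be used. The other, an at least 1.7-fold higher number from compound 1 to compound 2 (0.25 log units; that floor lies within the scatter), replaces the whole (4-ethylphenyl)amino group with pyrrolidin-1-yl, and it shows no size beyond the scatter. The best anchor is therefore a single number: compound 4 keeps a substituted phenyl on the amine nitrogen, as does compound 1 at 8990 nM.

No large step is expected in this assay, and the direction cannot be firmly told. The expected size is a step that the limit leaves unreadable from compound 3 to compound 4. The estimate for compound 4 is 8000 nM, with an expected range from 3000 nM to 20000 nM.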

Compound 4, half-maximal inhibitory concentration: 3830 nM
Beside the measured number, compound 4's estimate is 2.1-fold (0.32 log units) above it; the range from low to high includes it.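

In this assay, for the compounds shown here, 3-methoxyphenyl in place of 4-ethylphenyl on the amine nitrogen gives a 2.3-fold lower number from compound 1 to compound 4 (0.37 log units; beyond the scatter), the first step of readable size between two substituted phenyl groups at this position, so changing the phenyl group alone can move the read-out. Putting (3-methoxyphenyl)amino in place of pyrrolidin-1-yl on the double-bonded ring carbon gives an at least 4.1-fold lower number from compound 2 to compound 4 (0.62 log units; beyond the scatter), and the starting value of this step is only a limit, so its size is a floor, yet that floor clears the scatter as the earlier step between these two groups of substituents did not: the limit of > 16000 nM in this assay, at which 1 of the 4 values shown sits. 3-methoxyphenyl in place of 4-(trifluoromethyl)phenyl gives an at least 1.0-fold lower number from compound 3 to compound 4 (0.01 log units; that floor lies within the scatter), and the starting value here is also only a limit, so no order can be drawn for this pair: the limit of > 4000 nM in this assay, at which 1 of the 4 values shown sits.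

The compounds shown include no 4-methoxyphenyl or 3-ethylphenyl, so the effect of changing the group cannot be told apart from the effect of changing its place on the ring. Going by these compounds, how a phenyl ring carrying a carboxylic acid or an amine would read on this nitrogen also stays open.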